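The source may hold more compounds than are shown below. What is called first, only, known or untested is meant among the compounds shown, and "the series" means these compounds.

Measured compounds in a functional assay on CLL cells (Homo sapiens) for cytotoxicity, read by MTT assay, with a stated time of 48 h; on this read-out lower numbers stand for an effect already at smaller amounts and higher numbers for an effect only at larger amounts of compound:
- compound 1, `C=C(CC)C(=O)c1ccc(OCC(=O)NCC(=O)O)c(Cl)c1Cl`: compound 1 gives > 25000 nM
- compound 2, `C=C(CC)C(=O)c1ccc(OCC(=O)Nc2cccc(C(=O)O)c2)c(Cl)c1Cl`: compound 2 gives 20600 nM

The value of compound 1, > 25000 nM, is a limit of this assay, not a number, as the record of the limit of > 25000 nM in this assay, at which 1 of the 2 values shown sits, makes explicit. Compound 2, in this assay, gives 20600 nM. Among the compounds with values here, the one measured step, an at least 1.2-fold lower number from compound 1 to compound 2 (0.08 log units; that floor lies within the scatter), moves from the limit to a number, so its true size is known only as a floor, and that floor lies within the scatter.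

Compound 3, `C=C(CC)C(=O)c1ccc(OCC(=O)Nc2ccc(O)cc2)c(Cl)c1Cl`, is not yet measured. It differs from compound 1 by 4-hydroxyphenyl in place of carboxymethyl on an amide-type nitrogen. Like compound 2 it carries an aryl group on the amide nitrogen, but with a hydroxyl where compound 2 bears a carboxylic acid; no measured step covers that second exchange. Within the data shown here, the only step that bears on it is the one from compound 1 to compound 2, so a small downward move or none beyond the scatter is expected, with a fair chance that compound 3 again returns only the limit. Compound 3 is estimated at 16000 nM, between 5000 nM and 40000 nM. The step from compound 1 that this estimate means, an at least 1.5-fold lower number from compound 1 to compound 3 (0.19 log units; that floor lies within the scatter), is expected to stay near the floor set by compound 2.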

Compound 3, half-maximal effective concentration: 6400 nM
Beside the measured number, compound 3's estimate is 2.5-fold (0.40 log units) above it; measured number inside the range.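

In this assay, the place on the amide-type nitrogen now shows a change that clearly exceeds the scatter, an at least 3.9-fold lower number from compound 1 to compound 3 (0.59 log units; beyond the scatter), whereas the floor of the earlier step had stayed within it. The two aryl groups on this nitrogen also part from each other, with 4-hydroxyphenyl in place of 3-carboxyphenyl giving a 3.2-fold lower number from compound 2 to compound 3 (0.51 log units; beyond the scatter), so carrying an aryl group there does not alone fix the number. The value of compound 1 remains a limit and not a number, so the first of these steps is known only as a floor: the limit of > 25000 nM in this assay, at which 1 of the 3 values shown sits.

Going by these compounds, whether the change turns on the hydroxyl or on the loss of the carboxylic acid stays open. The compounds shown include no plain phenyl group on this nitrogen, and no amine or methoxy group in the hydroxyl's stead.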